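The source may hold more compounds than are shown below. What is called first, only, known or untested is meant among the compounds shown, and "the series" means these compounds.

Compound 1 `Cc1ccc2[nH]c(C(=O)N[C@H]3CN(S(=O)(=O)c4ccccc4)C[C@]3(C)C(=O)N[C@H]3CCCNC3)cc2c1` and compound 2 `O=C(N[C@H]1CN(S(=O)(=O)c2ccccc2)C[C@@H]1C(=O)NC[C@@H]1CCCN1)c1cc(-c2ccccc2Cl)on1` share a core, and both have been examined in an ADME assay on cells (Hepatocyte, Rattus norvegicus) for metabolic stability; a lower number here means slower removal, a higher number faster removal of the compound. Compound 1 gives 11 uL/min, while compound 2 gives 22 uL/min. The two numbers lie within the usual scatter of each other, so neither can be said to be cleared faster or slower than the other; compound 2 is simply the closer of the two to the new compound in structure.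

Compound 3 `O=CN1CCC[C@H](NC(=O)[C@H]2CN(S(=O)(=O)c3ccccc3)C[C@@H]2NC(=O)c2cc(-c3ccccc3Cl)on2)C1` is not yet measured. It differs from compound 2 in one place: a group of 8 heavy atoms (6 carbon, 1 nitrogen, 1 oxygen; one six-membered non-aromatic ring with 1 hetero atom) in place of a group of 6 heavy atoms (5 carbon, 1 nitrogen; one five-membered non-aromatic ring with 1 hetero atom), on an amide-type nitrogen. Among the measured compounds shown here, no step between two measured compounds matches this change, so there is nothing in the numbers at hand that fixes its size. On the two values that exist, the step from compound 2 to compound 3 is expected to be a modest rise in this assay, estimated at a 1.4-fold higher number from compound 2 to compound 3 (0.13 log units; within the scatter), which is within or only just beyond the scatter. Compound 3 is therefore estimated at 30 uL/min, with a range from 12 uL/min to 70 uL/min, to be set against the number once it is known.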

Compound 3, intrinsic clearance in a liver preparation (reported as CLH), per the amount of preparation that the assay uses: 97 uL/min
The estimate for compound 3 lay 3.2-fold (0.51 log units) below the measured number, and the stated range ends below it.
By their numbers in this assay, from the lowest: compounds 1 and 2 (each within the scatter of the next); then compound 3.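

On this amide-type nitrogen, putting the six-membered ring group in place of (pyrrolidin-2-yl)methyl gives a 4.4-fold higher number from compound 2 to compound 3 (0.64 log units; beyond the scatter) in this assay, the first difference among the compounds shown to lie beyond the scatter. The position is thus not indifferent to the group it carries: a change confined to this one place is enough to move the number clearly. This single step, however, alters several things at once, as the ring grows from five-membered to six-membered, the heavy-atom count goes from 6 to 8, and the hydrogen-bond donors go from 1 to 0, and no measurement at hand bears on what lies behind the rise.

The compounds shown therefore leave open which of these differences carries the step, and a (piperidin-2-yl)methyl group or a ring with a methyl on its nitrogen would each separate them in part. They also leave open whether the same change would give a step of similar size on the core of compound 1, or with a group other than 5-(2-chlorophenyl)isoxazole on the far amide.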